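This account rests on a few compounds, and the source may have more. Where it says the series, first, only, none or still open, it means among the compounds named here.

Three compounds that share one core have been measured in an ADME assay on microsomes from liver (Homo sapiens) for pharmacokinetics, read by LC-MS, with a stated time of 60 min, tested at 1 uM; a lower number here means slower removal, a higher number faster removal of the compound:

Compound 1 `C[C@@H]1COC[C@@H](C)N1S(=O)(=O)c1ccc(NC(=O)NCc2cccnc2)cc1`: 17 mL/min/kg
Compound 2 `O=C(NCc1cccnc1)Nc1ccc(S(=O)(=O)N2CC3(COC3)C2)cc1`: 7 mL/min/kg
Compound 3 `O=C(NCc1cccnc1)Nc1ccc(S(=O)(=O)N2CCCNCC2)cc1`: 6 mL/min/kg

Compound 3, at 6 mL/min/kg, stands at the low end of these numbers together with compound 2, with a 1.2-fold lower number from compound 2 to compound 3 (0.07 log units; within the scatter). Compound 1 stands apart from both. The next compound to be read is compound 4 `O=C(NCc1cccnc1)Nc1ccc(S(=O)(=O)N[C@H]2CC[C@H](O)CC2)cc1`, which keeps the shared core and differs from compound 3 in one place: (4-hydroxycyclohexyl)amino in place of 1,4-diazepan-1-yl on a sulfonyl sulfur. In words, this is (4-hydroxycyclohexyl)amino in place of 1,4-diazepan-1-yl on a sulfonyl sulfur.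

All three measured steps were changes on that same sulfonyl sulfur, and they bear on this one. They were modest at most: a 2.4-fold lower number from compound 1 to compound 2 (0.39 log units; beyond the scatter), and a 2.8-fold lower number from compound 1 to compound 3 (0.45 log units; beyond the scatter). Among the measured compounds shown here, none of the measured compounds carries the entering group, so the data give no direct precedent for it. A step of no greater size than these is therefore expected, most likely a slight rise that stays within the scatter. The expected step is a 1.3-fold higher number from compound 3 to compound 4 (0.12 log units; within the scatter). The estimate for compound 4 is 8 mL/min/kg, with an expected range from 4 mL/min/kg to 16 mL/min/kg.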

Compound 4, clearance: 2 mL/min/kg
Compound 4: middle estimate off by 4.0-fold (0.60 log units), on the high side, and the stated range ends above it.
By their numbers in this assay, from the lowest: compound 4; then compounds 3 and 2 (each within the scatter of the next); then compound 1.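

In this assay, the change to (4-hydroxycyclohexyl)amino on the sulfonyl sulfur gives a 3.0-fold lower number from compound 3 to compound 4 (0.48 log units; beyond the scatter) and a 3.5-fold lower number from compound 2 to compound 4 (0.54 log units; beyond the scatter) and also an 8.5-fold lower number from compound 1 to compound 4 (0.93 log units; beyond the scatter) as its three steps, each beyond the scatter, so compound 4 has the lowest number of the four. Compound 2 and compound 3 lay within the scatter of each other despite carrying different rings, and compound 4 now shows that this position can take the number lower than either of them did, here with a six-membered ring of carbon only that joins the sulfonyl sulfur through an amino group and not through a ring nitrogen. No evidence at hand accounts for this drop.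

The compounds shown do not separate the part played by the hydroxyl from that of the ring or the amino link, which a plain cyclohexylamino group or a 4-methoxycyclohexylamino group would address. They also leave open how much the defined stereocentres matter, and whether a carboxylic acid in place of the hydroxyl would give a number like that of compound 4.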